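This account rests on a few compounds, and the source may have more. Where it says the series, first, only, none or still open, it means among the compounds named here.

Compound 1 `COc1ccc2c(c1)C(=O)[C@H](O)[C@@H](c1cccc(O)c1O)O2` is one of three compounds that share the same core and were tested in a functional assay on RAW264.7 cells (Rattus norvegicus) for inhibition, with RAW264.7 (Mus musculus) as the target, read by Griess assay, with stated times of 2 h and 16 h; on this read-out lower numbers stand for stronger inhibition and higher numbers for weaker inhibition. In this assay compound 1 gives only a limit, > 100000 nM, rather than a number. The same limit is the point at which (the limit of > 100000 nM in this assay, at which 1 of the 3 values shown sits), so where compound 1 stands relative to the others can be stated only in one direction. Compound 2 `COc1cc(OC)c2c(c1)OC(c1cccc(O)c1O)C(O)C2=O`, which carries two methoxy groups on its core, gives 57600 nM in this assay. Compound 3 `Cc1cc2c(cc1C)C(=O)C(O)C(c1cccc(O)c1O)O2`, with two methyl groups on its core, gives 20700 nM in this assay. Both of these are numbers, and both sit at weaker inhibition than is usually of interest, while compound 1 sits at the limit.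

Compound 4 `COc1ccc2c(c1)C(=O)[C@@H](O)[C@H](c1cccc(O)c1O)O2` is the mirror image of compound 1: the two compounds have the same atoms and bonds and differ only in configuration as drawn: 2 of 2 stereo elements differ (all stereocentres are inverted: mirror images); a stereocentre at a saturated ring carbon is drawn R in compound 1 and S in compound 4; a stereocentre at a saturated ring carbon is drawn R in compound 1 and S in compound 4. Within the data shown here, no pair of measured compounds shows what this inversion alone does on this core, and compounds 2 and 3 differ from compound 1 in their ring substituents as well, so they give no direct guide to the step.

The step from compound 1 to compound 4 is therefore estimated with little confidence, an at least 1.4-fold lower number from compound 1 to compound 4 (0.15 log units; that floor lies within the scatter), and is as likely to land at the limit again as on a number. Compound 4 is expected to give about 70000 nM in this assay, within a range from 15000 nM to 300000 nM.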

Compound 4, half-maximal inhibitory concentration: > 100000 nM
Compound 4: a limit, no number; the forecaster's own chance of this, stated with the estimate: 50%; middle value at least 1.4-fold (0.15 log units) from the limit.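

In this assay compound 4 gives > 100000 nM, which is a limit and not a number. Among these compounds, compound 1 also gives a limit, so no step between compound 1 and compound 4 can be read. The compounds shown leave open whether inverting both stereocentres changes inhibition on the shared core at all, and in which direction.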